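The compounds below may be only part of what the source reports. "The series", "measured", "known", "first", "only" and "open" are said of these compounds alone.

Compound 1 `CCNC1=NS(=O)(=O)c2cc(Cl)ccc2N1` and compound 2 `CCCNC1=NS(=O)(=O)c2cc(Cl)ccc2N1` share a core and differ by methyl in place of hydrogen on a saturated chain carbon, two bonds along the chain from an amine nitrogen. In a functional assay (aorta) with Rattus norvegicus as the target (on this read-out lower numbers stand for an effect already at smaller amounts and higher numbers for an effect only at larger amounts of compound), compound 1 gives 39.9 uM, and compound 2 gives 55.5 uM, so that a 1.4-fold higher number from compound 1 to compound 2 (0.14 log units; within the scatter). Compound 3 `CCC(C)NC1=NS(=O)(=O)c2cc(I)ccc2N1` carries another core; the difference between the two cores is not broken down here. In this assay compound 3 gives 1.3 uM, the lowest of the three values. Compound 4 `CC(C)C(C)NC1=NS(=O)(=O)c2cc(I)ccc2N1` differs from compound 3 by methyl in place of hydrogen on a saturated chain carbon bound to two saturated chain carbons. This is the same kind of change as that from compound 1 to compound 2, though the place differs: there the carbon was two bonds along the chain from an amine nitrogen, here it is bound to two saturated chain carbons. Because a 1.4-fold higher number from compound 1 to compound 2 (0.14 log units; within the scatter) stayed within the scatter, a step of about a 1.4-fold higher number from compound 3 to compound 4 (0.14 log units; within the scatter) is expected for compound 4. Compound 4 is therefore estimated at 1.8 uM, between 0.6 uM and 5.5 uM.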

Compound 4, concentration for half-maximal effect: 0.94 uM
Estimate against measurement, compound 4: 1.9-fold (0.28 log units) above; the range from low to high includes it.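

In this assay the exchange of hydrogen for methyl gives a 1.4-fold lower number from compound 3 to compound 4 (0.14 log units; within the scatter). Set beside the earlier step, the change reads alike on the two cores: the same change on two cores in this assay, a 1.4-fold higher number (0.14 log units; within the scatter) from compound 1 to compound 2 and a 1.4-fold lower number (0.14 log units; within the scatter) from compound 3 to compound 4, 1.9-fold (0.28 log units) apart, within the scatter of two such steps. This rests on one pair per core, with the methyl at a different place in each, and it does not show that the change would behave alike on other cores or at other places.

The compounds shown leave open what a longer chain, a cyclohexyl group, or a chain ending in an amine or a carboxylic acid would give in this assay. They also leave open how much of the gap between compound 3 and compounds 1 and 2 belongs to the core and how much to the chain.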